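This account rests on a few compounds, and the source may have more. Where it says the series, first, only, none or still open, it means among the compounds named here.

Three measured compounds share one core and differ in the group on an aromatic nitrogen: compound 1 (`CCCCn1nc(C(=O)N[C@H]2COc3ccccc3N(C)C2=S)nc1Cc1ccccc1`), compound 2 (`CN1C(=S)[C@@H](NC(=O)c2nc(Cc3ccccc3)n(CCC(F)(F)F)n2)COc2ccccc21`) and compound 3 (`CN1C(=S)[C@@H](NC(=O)c2nc(Cc3ccccc3)n(C3CCOCC3)n2)COc2ccccc21`). In a toxicity assay on HT-29 cells (Homo sapiens) for cytotoxicity (on this read-out higher numbers stand for lower toxicity in this test and lower numbers for higher toxicity in this test), compound 1 gives > 100000 nM as a limit of the test, not a number. Compound 2 gives > 100000 nM in this assay and this too is a limit. Compound 3, the starting point here, gives > 100000 nM in this assay and this is likewise a limit, so it has no exact value.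

Compound 4 (`CN1C(=S)[C@@H](NC(=O)c2nc(Cc3ccccc3)n(CC3CCOCC3)n2)COc2ccccc21`) carries (oxan-4-yl)methyl in place of oxan-4-yl on an aromatic nitrogen. Bearing on this are a step that the two limits leave unreadable from compound 1 to compound 3 and a step that the two limits leave unreadable from compound 2 to compound 3 at that same nitrogen, along with a step that the two limits leave unreadable from compound 1 to compound 2 in the chain. None of these has a readable size (because of the limit of > 100000 nM in this assay, at which 3 of the 3 values shown sit). They therefore give no direction for the new change. The estimated step (a number no higher from compound 3 to compound 4 (the limit leaves the size open)) is expected to stay within the usual scatter, with no direction. For compound 4 the estimate is 100000 nM with an expected range from 50000 nM to 200000 nM in this test, and a report of only a limit is the likely outcome.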

Compound 4, half-maximal cytotoxic concentration: > 100000 nM
Compound 4 ended at the assay's limit; the forecaster's own chance of this, stated with the estimate: 90%; the middle value sits exactly at the limit.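

Compound 4 gives > 100000 nM in this assay, and this is a limit, not a number. The steps to compound 4 from compound 1, compound 2 and compound 3 therefore cannot be read, because all four compounds share one limit: the limit of > 100000 nM in this assay, at which 4 of the 4 values shown sit. The compounds shown leave open whether any group on this aromatic nitrogen changes toxicity in this assay.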